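Aryl substituent swap in the succinimide-piperazine amide series

The compounds below may be only part of what the source reports. "The series", "measured", "known", "first", "only" and "open" are said of these compounds alone.

Measured so far:
compound 1, `CC(C(=O)N1CCN(c2ccccc2C(F)(F)F)CC1)N1C(=O)CCC1=O`: 100%
compound 2, `CCC(C(=O)N1CCN(c2ccccc2)CC1)N1C(=O)CCC1=O`: 75%
compound 3, `CCC(C(=O)N1CCN(c2ccccc2C(F)(F)F)CC1)N1C(=O)CCC1=O`: 25%

In a functional assay on the whole organism (strain Swiss) with Mus musculus as the target, in the maximal electroshock model, with a stated time of 0.5 h, at a dose of 300 mg/kg by the intraperitoneal route (on this read-out higher numbers stand for a stronger effect at the one dose given and lower numbers for a weaker effect), compound 1 gives 100%, the highest of the three numbers; compound 2 gives 75% and compound 3 gives 25%. Two single-point steps are known. Methyl in place of hydrogen on the chain carbon gave a number 75 percentage points lower from compound 1 to compound 3 (beyond the scatter). Trifluoromethyl in place of hydrogen on the aromatic carbon gave a number 50 percentage points lower from compound 2 to compound 3 (beyond the scatter).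

Compound 4, `CC(C(=O)N1CCN(c2ccccc2Cl)CC1)N1C(=O)CCC1=O`, differs from compound 1 by chloro in place of trifluoromethyl on an aromatic carbon. Among the compounds with values here, no measured step covers this exchange directly. The nearest is a number 50 percentage points lower from compound 2 to compound 3 (beyond the scatter), where trifluoromethyl entered on the aromatic carbon within the ethyl branch and the number fell; here trifluoromethyl leaves and chloro enters at the same place within the methyl branch, where compound 1 already stands at the top of the scale, so no rise can be seen in this assay. A modest fall or a step within the scatter is expected.

Compound 4 is therefore estimated at 90% in this assay, within 60% to 100%, an expected step of a number 10 percentage points lower from compound 1 to compound 4 (within the scatter).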

Compound 4, a percentage reported as activity, at one dose (the size of the read-out at that dose, not a potency): 0%
The estimate for compound 4 lay 90 percentage points above the measured number, and the stated range ends above it.
By their numbers in this assay, from the lowest: compound 4; then compound 3; then compound 2; then compound 1.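

Within the methyl branch, this aromatic carbon, ortho to a large group, proves highly sensitive to the identity of its substituent: in this assay, the exchange of trifluoromethyl for chloro gives a number 100 percentage points lower from compound 1 to compound 4 (beyond the scatter), a step that spans the whole range of numbers in the series so far. The earlier step at this carbon, a number 50 percentage points lower from compound 2 to compound 3 (beyond the scatter), could suggest that trifluoromethyl is a liability there, but the new step shows that it does not count against activity in every setting, since the methyl-branch compound that carries it stands far above its chloro counterpart. Nothing available explains the size of this step.

The compounds shown leave open how hydrogen, methoxy or nitrile at this aromatic carbon would read within the methyl branch. They also leave open whether the same exchange of trifluoromethyl for chloro would give a step of similar size within the ethyl branch.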